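Pentafluorophenyl pyrrolidine series: the mirror-image question

The source may hold more compounds than are shown below. What is called first, only, known or untested is meant among the compounds shown, and "the series" means these compounds.

Measured so far, as inhibition in an assay on isolated protein for inhibition of alpha-mannosidase (Canavalia ensiformis), tested at 1000 uM; on this read-out lower numbers stand for less inhibition and higher numbers for more inhibition at the one concentration tested (going by the name of the read-out):
compound 1 `Cc1ccc([C@]2(CO)NC[C@@H](O)[C@@H]2O)cc1`: 0%
compound 2 `OC[C@]1(c2c(F)c(F)c(F)c(F)c2F)NC[C@H](O)[C@H]1O`: 6.6%
compound 3 `COc1cccc([C@]2(CO)NC[C@@H](O)[C@@H]2O)c1`: 0%

All three share one core and differ in the aryl group. Among the compounds with values here, the read-outs in this assay sit together: compound 2 gives 6.6%, and its gaps to compound 1 and to compound 3 are each within the scatter, so no compound is set apart from the others. Nothing in the measured set shows a pattern that exceeds the scatter.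

Compound 4 `OC[C@@]1(c2c(F)c(F)c(F)c(F)c2F)NC[C@@H](O)[C@@H]1O` is the mirror image of compound 2. The change is the two compounds have the same atoms and bonds and differ only in configuration as drawn: 3 of 3 stereo elements differ (all stereocentres are inverted: mirror images); a stereocentre at a saturated ring carbon is drawn S in compound 2 and R in compound 4; a stereocentre at a saturated ring carbon is drawn S in compound 2 and R in compound 4; a stereocentre at a saturated ring carbon is drawn S in compound 2 and R in compound 4. Within the data shown here, no measured pair of this kind is available in this assay, so nothing is known here about how the two enantiomers compare.

With compound 2 at 6.6% and the whole set giving small read-outs in this assay, the step expected for compound 4 is a number 1.6 percentage points lower from compound 2 to compound 4 (within the scatter), that is, none beyond the scatter. For compound 4 the value in this assay is estimated at 5%, with a range from 0% to 25%.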

Compound 4, a percentage reported as inhibition, at one concentration (the size of the read-out at that concentration, not a potency): 0%
Compound 4: middle estimate off by 5 percentage points, on the high side; measured number inside the range.
By their numbers in this assay, from the lowest: compounds 1, 3, 4 and 2 (each within the scatter of the next).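

Within the data shown here, the first mirror-image pair in this assay gives a number 6.6 percentage points lower from compound 2 to compound 4 (within the scatter), so inverting all three stereocentres opens no gap that can be told from the scatter at the one concentration tested. At this level of read-out, neither configuration of the pentafluorophenyl compound is set apart from the other. Unlike the earlier comparisons, which all changed the aryl group, this one bears on configuration alone: the fact that compounds 2 and 4 differ only in the configuration as drawn

On these data alone, it remains open whether mirror images would separate in a series with read-outs well clear of the scatter, for instance with an aryl group carrying a carboxylic acid or an amine. The compounds shown also leave open whether the pentafluorophenyl result carries over to the enantiomers of the other aryl groups.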